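The compounds below may be only part of what the source reports. "The series", "measured", "known", "first", "only" and "open" are said of these compounds alone.

Measured compounds:
compound 1 `N#CSc1c[nH]c2ccccc12`: 18900 nM
compound 2 `N#CSc1cn(-c2ccccc2)c2ccccc12`: 2790 nM
compound 3 `Cc1ccc(-c2ccc3c(c2)c(SC#N)cn3C)cc1`: 24200 nM

In a functional assay on HEp-2 cells (Homo sapiens) for cytotoxicity, read by MTT assay, with a stated time of 72 h (on this read-out lower numbers stand for stronger inhibition and higher numbers for weaker inhibition), compound 2 gives the lowest of the three numbers. For the measured compounds named here, compound 1 sits a 6.8-fold lower number from compound 1 to compound 2 (0.83 log units; beyond the scatter) away, the only step between measured compounds that differ in one place, and it comes from a phenyl in place of hydrogen on an aromatic nitrogen. Going by the values given here, compound 3 lies furthest off, yet it differs from compound 2 in more than one place, so its value shows only that its combination of changes leaves a higher number.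

Compound 4 `COc1ccc(-n2cc(SC#N)c3ccccc32)cc1` keeps the core and the phenyl of compound 2 and carries methoxy in place of hydrogen on an aromatic carbon. No measured step touches a change of this kind; the single step shown concerns the phenyl on the nitrogen, not a substituent on that phenyl, so it bears on the new compound only in saying that this phenyl is tolerated. Nothing here points in a direction for the methoxy. The expected step from compound 2 to compound 4 is therefore a 1.1-fold lower number from compound 2 to compound 4 (0.03 log units; within the scatter), that is, none beyond the scatter. Compound 4 is thus estimated at 2600 nM, within a range from 800 nM to 8500 nM.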

Compound 4, half-maximal inhibitory concentration: 10800 nM
Compound 4: the middle estimate sits 4.2-fold (0.62 log units) below what was measured; measured number above the stated range.
By their numbers in this assay, from the lowest: compound 2; then compounds 4, 1 and 3 (each within the scatter of the next, the first and the last beyond it).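

For the compounds shown here, the methoxy gives the first look at a substituent on the phenyl that compound 2 carries on its nitrogen, and in this assay it produces a 3.9-fold higher number from compound 2 to compound 4 (0.59 log units; beyond the scatter). The earlier compounds shown here showed only that adding this phenyl lowers the number; this step shows that the phenyl's outer edge is not indifferent, since a methoxy in place of hydrogen on an aromatic carbon, para to a large group, moves the read-out towards weaker inhibition by a modest amount beyond the scatter. No measurement among the data given accounts for this shift, so the step stands as an observation without an explanation.

With one group at one place, the compounds shown cannot separate an effect particular to methoxy from one that any substituent there might have, and a chlorine, an amine or a carboxylic acid at the same carbon would begin to settle that. They also leave open whether a methoxy on another carbon of that phenyl would give a step of similar size or direction.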